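Phthalimide-triazole thioethers: cytotoxicity on gastric carcinoma cells

The source may hold more compounds than are shown below. What is called first, only, known or untested is meant among the compounds shown, and "the series" means these compounds.

Working notes on a small set of triazole thioethers tested in a functional assay on MKN-45 cells (Homo sapiens) for cytotoxicity, read by MTT assay, with a stated time of 48 h; a lower number here means a stronger inhibitor, a higher number a weaker inhibitor. Compound 1 `CCc1nnc(SCC(=O)c2ccccc2)n1N1C(=O)c2ccccc2C1=O` gives > 200000 nM, a limit of the assay rather than a number. Compound 2 `CCCc1nnc(SCc2ccccc2)n1N1C(=O)c2ccccc2C1=O` likewise reaches only the limit, > 200000 nM. Compound 3 `C#CCSc1nnc(-c2cc(OC)c(OC)c(OC)c2)n1N1C(=O)c2ccccc2C1=O` also stops at the limit, > 200000 nM. Compound 3 therefore stands with every other value shown, at the limit of > 200000 nM in this assay, at which 3 of the 3 values shown sit, and no ordering among the three is possible.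

Compound 4 `COc1ccc(C(=O)CSc2nnc(-c3cc(OC)c(OC)c(OC)c3)n2N2C(=O)c3ccccc3C2=O)cc1` differs from compound 3 by (4-methoxyphenyl)carbonyl in place of ethynyl on a saturated chain carbon bound to a sulfur. Among the compounds with values here, no measured step covers this change, so the expected step of an at least 1.3-fold lower number from compound 3 to compound 4 (0.12 log units; that floor lies within the scatter) is judged small, most likely none beyond the scatter, and compound 4 is expected to remain weak. The estimate for compound 4 in this assay is 150000 nM, within 30000 nM to 400000 nM, with a fair chance that again only a limit is reported.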

Compound 4, half-maximal inhibitory concentration: 37200 nM
For compound 4 the middle estimate is 4.0-fold (0.61 log units) above the measured one; measured number inside the range.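

Replacing ethynyl with (4-methoxyphenyl)carbonyl on a saturated chain carbon bound to a sulfur shows that this position can move the series off its limit (an at least 5.3-fold lower number from compound 3 to compound 4 (0.73 log units; beyond the scatter)). On these data alone, compound 3 supplies only a limit, so the true size of the step remains unknown and may be larger. Compound 4 is the only compound shown with a measured number:  the limit of > 200000 nM in this assay, at which 3 of the 4 values shown sit.

Whether the carbonyl, the aromatic ring or the methoxy group accounts for the step remains open. So does the effect of an amine or a carboxylic acid on the same chain carbon.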